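This account rests on a few compounds, and the source may have more. Where it says the series, first, only, none or still open, it means among the compounds named here.

Working notes on the series. Compound 1 `COc1c(C)ccc2c1CCC2c1ncc[nH]1` and compound 2 `Cn1nccc1-c1cccc2c1CCC2c1ncc[nH]1` share a core and differ in the groups placed on its six-membered ring. In a functional assay on CHO cells for agonist activity at Alpha-1A adrenergic receptor (Homo sapiens), read by FLIPR and calcium flux (on this read-out lower numbers stand for an effect already at smaller amounts and higher numbers for an effect only at larger amounts of compound), compound 1 gives 167 nM and compound 2 gives 278 nM. Of the two numbers compound 2 has the larger, yet its gap to compound 1 lies within the scatter, so no order between them can be stated.

Compound 3 `c1cc(-c2cn[nH]c2)c2c(c1)C(c1ncc[nH]1)CC2` is not yet measured. It differs from compound 2 by a single change: 1H-pyrazol-4-yl in place of 1-methyl-1H-pyrazol-5-yl on an aromatic carbon. Going by the values given here, no step between two measured compounds covers this kind of exchange, so nothing on file tells its size or direction. With only the two values above as a footing, the step from compound 2 to compound 3 is expected to be small, a 1.1-fold lower number from compound 2 to compound 3 (0.03 log units; within the scatter), and not to fall beyond the scatter in either direction. Compound 3 is therefore estimated at 260 nM in this assay, with a range from 80 nM to 850 nM.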

Compound 3, half-maximal effective concentration: 14 nM
Beside the measured number, compound 3's estimate is 19-fold (1.27 log units) above it; measured number below the stated range.
By their numbers in this assay, from the lowest: compound 3; then compounds 1 and 2 (each within the scatter of the next).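

In this assay, going by these compounds alone, the exchange of 1-methyl-1H-pyrazol-5-yl for 1H-pyrazol-4-yl on an aromatic carbon brings a 20-fold lower number from compound 2 to compound 3 (1.30 log units; beyond the scatter) and shows that this place on the shared core responds strongly to the group it carries, which the earlier compounds could not show. Both groups are five-membered aromatic rings with 2 hetero atoms, and the entering one differs only by one heavy atom fewer, a hydrogen-bond donor and one hydrogen-bond acceptor fewer, so a small exchange by these counts carries a large step. Nothing on file gives a reason for the size of this step.

The exchange removes the methyl group and moves the point of attachment at once, and the compounds shown do not separate the two; 1-methyl-1H-pyrazol-4-yl and 1H-pyrazol-5-yl would do so. On these data alone, how a group without a five-membered aromatic ring, such as an amine or a carboxylic acid, would fare at this place also stays open.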